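The compounds below may be only part of what the source reports. "The series", "measured", "known", "first", "only" and "open" are said of these compounds alone.

Compound 2 `CCC[C@H](c1ccc(C(=O)NCc2nn[nH]n2)cc1)N1C(=O)C(c2cc(Cl)cc(Cl)c2)=N[C@]12CC[C@@H](C(C)(C)C)CC2` gives 220 nM in a functional assay on CHO cells for antagonist activity at Glucagon receptor (Homo sapiens), read by cAMP accumulation, with stated times of 30 min and 45 min (on this read-out higher numbers stand for weaker inhibition and lower numbers for stronger inhibition), the lowest number among the measured compounds. Compound 3 `CC(C)(C)[C@H]1CC[C@]2(CC1)N=C(c1cccc(Cl)c1)C(=O)N2Cc1ccc(C(=O)NCCC(=O)O)cc1` gives 770 nM in this assay, and compound 1 `CC(C)[C@H](c1ccc(C(=O)NCc2nn[nH]n2)cc1)N1C(=O)C(c2cc(Cl)cc(Cl)c2)=N[C@]12CC[C@@H](C(C)(C)C)CC2` gives 2200 nM in this assay. For the measured compounds named here, the one step of a single change, a 10-fold lower number from compound 1 to compound 2 (1.00 log units; beyond the scatter), shows that the shape of the chain at this carbon matters. Compound 4 `CCCCC[C@H](c1ccc(C(=O)NCc2nn[nH]n2)cc1)N1C(=O)C(c2cc(Cl)cc(Cl)c2)=N[C@]12CC[C@@H](C(C)(C)C)CC2` carries ethyl in place of hydrogen on a saturated chain carbon, four bonds along the chain from an amide-type nitrogen in a ring and an aromatic carbon, a further lengthening of that same chain. Going by the values given here, only the step from compound 1 to compound 2 bears on it, and it concerns branching rather than length, so the expected step of a 1.5-fold lower number from compound 2 to compound 4 (0.17 log units; within the scatter) in this assay is small and uncertain in direction. Compound 4 is therefore estimated at 150 nM in this assay, within a range of 50 nM to 600 nM.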

Compound 4, half-maximal inhibitory concentration: 130 nM
Compound 4: the middle estimate sits 1.2-fold (0.06 log units) above what was measured; the range from low to high includes it.
By their numbers in this assay, from the lowest: compounds 4 and 2 (each within the scatter of the next); then compound 3; then compound 1.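

Going from propyl to pentyl in this assay gives a 1.7-fold lower number from compound 2 to compound 4 (0.23 log units; within the scatter) so the added ethyl leaves the number within the scatter of compound 2. Pentyl in place of isopropyl gives a 17-fold lower number from compound 1 to compound 4 (1.23 log units; beyond the scatter) which shows that this carbon accepts a longer unbranched chain without losing the difference from the branched isopropyl of compound 1. Nothing available explains these differences.

The compounds shown leave open whether a chain longer than pentyl would stay at this level. They also leave open how a chain ending in an amine or a carboxylic acid would read here.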